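Chain Extension on a Chloroacetamide-Tethered Nucleotide Series

The compounds below may be only part of what the source reports. "The series", "measured", "known", "first", "only" and "open" are said of these compounds alone.

Measured compounds:
Compound 1 `O=C(CI)NCCCC(=O)NCCCCCCNc1ncnc2c1ncn2[C@@H]1O[C@H](COP(=O)(O)OP(=O)(O)OP(=O)(O)O)[C@@H](O)[C@H]1O`: 0%
Compound 2 `O=C(CI)NCCCCCCCNc1ncnc2c1ncn2[C@@H]1O[C@H](COP(=O)(O)OP(=O)(O)OP(=O)(O)O)[C@@H](O)[C@H]1O`: 30%

In an assay on isolated protein for inhibition of hexokinase-2 (Rattus norvegicus), with a stated time of 6 h, tested at 10 mM (a lower number here means less inhibition, a higher number more inhibition at the concentration tested (going by the name of the read-out)), compound 1 gives 0%, while compound 2 gives 30%. Compound 2 therefore stands highest of the two numbers, with compound 1 as its nearest neighbour at a number lower by a margin beyond the scatter. Among the compounds with values here, the one measured step is a number 30 percentage points higher from compound 1 to compound 2 (beyond the scatter). The structural change in that step is a group of 6 heavy atoms (3 carbon, 1 nitrogen, 1 oxygen, 1 iodine; no ring) in place of a group of 11 heavy atoms (6 carbon, 2 nitrogen, 2 oxygen, 1 iodine; no ring), on a saturated chain carbon, six bonds along the chain from a nitrogen on an aromatic ring.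

Compound 3 `O=C(CI)NCCCCCCCCNc1ncnc2c1ncn2[C@@H]1O[C@H](COP(=O)(O)OP(=O)(O)OP(=O)(O)O)[C@@H](O)[C@H]1O` is not yet measured. Its difference from compound 2 is (((iodomethyl)carbonyl)amino)methyl in place of ((iodomethyl)carbonyl)amino on a saturated chain carbon, seven bonds along the chain from a nitrogen on an aromatic ring, which adds one methylene to the chain without altering the terminal group. Within the data shown here, no measured step matches this change closely; the step from compound 1 to compound 2 involved a much larger rearrangement, so it bears only loosely on it. A step of small size in either direction, perhaps none beyond the scatter, is expected, as a number 5 percentage points higher from compound 2 to compound 3 (within the scatter). For compound 3 the estimated value in this assay is 35%, ranging from 10% to 60%.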

Compound 3, a percentage reported as inhibition, at one concentration (the size of the read-out at that concentration, not a potency): 41%
For compound 3 the middle estimate is 6 percentage points below the measured one; measured number inside the range.
By their numbers in this assay, from the lowest: compound 1; then compound 2; then compound 3.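

In this assay, (((iodomethyl)carbonyl)amino)methyl in place of ((iodomethyl)carbonyl)amino, on a saturated chain carbon, seven bonds along the chain from a nitrogen on an aromatic ring, gives a number 11 percentage points higher from compound 2 to compound 3 (beyond the scatter). This shows what the earlier pair could not: a methylene added to the chain, with the terminal group unchanged, moves the read-out beyond the scatter on its own, whereas the earlier step exchanged a much larger group. The replacement of the larger group of compound 1 now reaches a number 41 percentage points higher from compound 1 to compound 3 (beyond the scatter), and the step is large rather than modest, but no measurement on hand explains why the number rises with this change.

Going by these compounds, the two chain lengths in compound 2 and compound 3 give a single step and no trend, so it remains open whether a longer chain would raise the inhibition further, level off or reverse it. Also open is whether the gain depends on the iodomethyl end, as a chloromethyl carbonyl group or a plain amine at the chain end would test, and the read-out at one concentration gives no potency for any of these compounds.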